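Bromo in place of 4-chlorophenyl: a cytotoxicity expectation

The source may hold more compounds than are shown below. What is called first, only, known or untested is meant among the compounds shown, and "the series" means these compounds.

Measured compounds:
- compound 1, `Cc1nc(Cl)sc1S(=O)(=O)N1CCC(N2CCC(C)CC2)CC1`: > 10000 nM
- compound 2, `CC1CCN(C2CCN(S(=O)(=O)c3ccc(C#N)cc3)CC2)CC1`: > 5000 nM
- compound 3, `CC1CCN(C2CCN(S(=O)(=O)c3ccccc3-c3ccc(Cl)cc3)CC2)CC1`: > 5000 nM

In an ADME assay on HCT-116 cells (Homo sapiens) for cytotoxicity, read by CellTiter-Glo, with a stated time of 72 h (a lower number here means a stronger inhibitor, a higher number a weaker inhibitor), compound 1 gives > 10000 nM, which is a limit of the assay and not a number. Compound 2 gives > 5000 nM, again a limit. Compound 3 gives > 5000 nM, also a limit. Compound 3 therefore stands at the limit of > 5000 nM in this assay, at which 2 of the 3 values shown sit, together with compound 2, while compound 1 sits at the limit of > 10000 nM in this assay, at which 1 of the 3 values shown sits. Among the measured compounds shown here, the one step between measured compounds, a step that the two limits leave unreadable from compound 1 to compound 2, cannot be read, so no measured step gives a size that bears on the change to compound 4.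

Compound 4 is `CC1CCN(C2CCN(S(=O)(=O)c3ccccc3Br)CC2)CC1`. It differs from compound 3 in one place: bromo in place of 4-chlorophenyl on an aromatic carbon.

With every measured value a limit and no readable step, compound 4 is expected to stay weak as well, most likely again as a limit. Compound 4 is estimated at 8000 nM, with a range from 3000 nM to 30000 nM. This corresponds to an expected step that the limit leaves unreadable from compound 3 to compound 4, which is not expected to exceed the scatter.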

Compound 4, half-maximal inhibitory concentration: > 5000 nM
Compound 4: a limit, no number; the forecaster's own chance of this, stated with the estimate: 85%; the middle value is on the limit's open side.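

Compound 4 also ends at a limit of the assay and not a number, so its steps from compound 1, compound 2 and compound 3 cannot be read: the limit of > 5000 nM in this assay, at which 3 of the 4 values shown sit.

The compounds shown leave open whether exchanging 4-chlorophenyl for bromo changes anything in this assay, since no compound here has a number.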